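Branched Ester Side Chains on the Shared Core

The source may hold more compounds than are shown below. What is called first, only, known or untested is meant among the compounds shown, and "the series" means these compounds.

Compound 1 `COC(=O)CCNC(=O)Cn1cc(C2=C(c3c[nH]c4ccccc34)C(=O)N(C)C2=O)c2ccccc21` carries a 2-(methoxycarbonyl)ethyl group on an amide-type nitrogen. In a functional assay on BGC-823 cells (Homo sapiens) for cytotoxicity, read by MTT assay, with a stated time of 24 h (a higher number here means a weaker inhibitor, a lower number a stronger inhibitor), compound 1 gives 44900 nM, the highest of the two plain numbers shown. Compound 3 `COC(=O)[C@@H](CO)NC(=O)Cn1cc(C2=C(c3c[nH]c4ccccc34)C(=O)N(C)C2=O)c2ccccc21` gives 28900 nM in this assay, and the step of a 1.6-fold lower number from compound 1 to compound 3 (0.19 log units; within the scatter) lies within the scatter. Compound 2 `CC[C@H](C)[C@@H](NC(=O)Cn1cc(C2=C(c3c[nH]c4ccccc34)C(=O)N(C)C2=O)c2ccccc21)C(=O)OC` reaches only a limit of the assay, > 100000 nM (the limit of > 100000 nM in this assay, at which 1 of the 3 values shown sits). The step of an at least 2.2-fold higher number from compound 1 to compound 2 (0.34 log units; beyond the scatter) is therefore beyond the scatter, and so is an at least 3.4-fold lower number from compound 2 to compound 3 (0.53 log units; beyond the scatter).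

Compound 4 `COC(=O)[C@H](NC(=O)Cn1cc(C2=C(c3c[nH]c4ccccc34)C(=O)N(C)C2=O)c2ccccc21)C(C)C` has not yet been measured. It differs from compound 1 in a single place: 1-(methoxycarbonyl)-2-methylpropyl in place of 2-(methoxycarbonyl)ethyl on an amide-type nitrogen. Like the change from compound 1 to compound 2, this puts a branched alkyl on the saturated chain carbon bound to the amide-type nitrogen and the carbonyl carbon, with sec-butyl there in compound 2 and the smaller branched group in compound 4. Of the three measured steps, only an at least 2.2-fold higher number from compound 1 to compound 2 (0.34 log units; beyond the scatter) bears directly on this change, and it pointed toward a weaker inhibitor. A step of similar direction, at least modest, is expected here, with a real chance that only a limit is reported. Compound 4 is expected to give 80000 nM, within a range of 35000 nM to 200000 nM. The estimated step is a 1.8-fold higher number from compound 1 to compound 4 (0.25 log units; within the scatter).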

Compound 4, half-maximal inhibitory concentration: 48200 nM
For compound 4 the middle estimate is 1.7-fold (0.22 log units) above the measured one; low and high end bracket the measured number.
By their numbers in this assay, from the lowest: compounds 3, 1 and 4 (each within the scatter of the next). At a limit, above all of these: compound 2.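

Compound 4 shows that a branched group on the saturated chain carbon bound to an amide-type nitrogen and a carbonyl carbon need not push the number out of reach in this assay: with isopropyl there, the readings are a 1.1-fold higher number from compound 1 to compound 4 (0.03 log units; within the scatter) and a 1.7-fold higher number from compound 3 to compound 4 (0.22 log units; within the scatter), and both steps lie within the scatter. The real separation in this small set falls between isopropyl and sec-butyl, with hydrogen in place of methyl, three bonds along the chain, giving an at least 2.0-fold lower number from compound 2 to compound 4 (0.31 log units; beyond the scatter), so among these compounds branching as such does not go with the loss seen for compound 2. Compound 2 remains a limit of the assay, so this step has a bound but no exact size: the limit of > 100000 nM in this assay, at which 1 of the 4 values shown sits.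

All the compounds shown keep the methoxycarbonyl group, so the effect of a free carboxylic acid or a primary amide in its place remains open. Also open, on these data alone, is how a benzyl group or a straight butyl chain on the same saturated chain carbon would read.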